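This account rests on a few compounds, and the source may have more. Where it says the series, first, only, none or still open, it means among the compounds named here.

Of the compounds shown here, three sharing one core have been tested in an ADME assay on CCRF-HSB-2 cells (Homo sapiens) for cytotoxicity, with a stated time of 7 days; a lower number here means that less compound is tolerated, a higher number that more compound is tolerated: compound 1 (`CNc1nc(N)nc2c1ncn2/C=C1/CC1(CO)CO`), compound 2 (`CCOc1nc(N)nc2c1ncn2/C=C1/CC1(CO)CO`) and compound 3 (`CCCOc1nc(N)nc2c1ncn2/C=C1/CC1(CO)CO`). Compound 1 gives > 20000 nM, which is a limit of the assay. Compound 2 gives > 20000 nM, also a limit. Compound 3 gives > 20000 nM, again a limit and not a number. Compound 3 therefore stands with the other two, at the limit of > 20000 nM in this assay, at which 3 of the 3 values shown sit.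

The next compound, compound 4 (`Nc1nc(SCc2ccccc2)c2ncn(/C=C3/CC3(CO)CO)c2n1`), carries benzylsulfanyl in place of propoxy on an aromatic carbon. The measured changes at this carbon are a step that the two limits leave unreadable from compound 1 to compound 2, a step that the two limits leave unreadable from compound 1 to compound 3 and a step that the two limits leave unreadable from compound 2 to compound 3. Within the data shown here, none of them has a size that can be read, so they offer no measured step to carry over. Among the measured compounds shown here, they show only that the three groups tried so far all end at the same limit. For the measured compounds named here, no step beyond the scatter is therefore expected in this assay, although a fall cannot be excluded for a group with an aromatic ring, which none of the measured compounds has at this carbon. The expected change is a number no higher from compound 3 to compound 4 (the limit leaves the size open). Compound 4 is estimated at 20000 nM, within an expected range of 7000 nM to 50000 nM.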

Compound 4, half-maximal cytotoxic concentration: > 100000 nM
Compound 4 was reported as a limit; the forecaster's own chance of this, stated with the estimate: 75%; at least 5.0-fold (0.69 log units) between middle value and limit.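

Among these compounds, compound 4, like compound 1, compound 2 and compound 3, ends at a limit in this assay, and no step between compound 4 and any of them can be read. The compounds shown leave open whether benzylsulfanyl differs from propoxy, ethoxy or methylamino at this carbon.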